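The source may hold more compounds than are shown below. What is called first, only, known or untested is meant among the compounds shown, and "the series" means these compounds.

Compound 1 `Cc1nnc(Sc2cc(NC(=O)c3ccc(Cl)cc3)c3ccccc3c2O)s1`: > 100000 nM
Compound 2 `COc1cccc(C(=O)Nc2cc(Sc3ncn[nH]3)c(O)c3ccccc23)c1`: > 100000 nM

In a functional assay on HCT-116 cells (Homo sapiens) for antiproliferative activity, read by MTT assay, with a stated time of 48 h (a higher number here means a weaker inhibitor, a lower number a stronger inhibitor), compound 1 gives > 100000 nM, which is a limit of the assay and not a number. Compound 2 likewise gives > 100000 nM in this assay, again a limit and not a number. Among the compounds with values here, compound 1 thus stands at the limit of > 100000 nM in this assay, at which 2 of the 2 values shown sit, and nothing among the measured compounds places it higher or lower than that.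

Compound 3 `Cn1nnnc1Sc1cc(NC(=O)c2ccc(Cl)cc2)c2ccccc2c1O` has not yet been measured in this assay. It differs from compound 1 by 1-methyl-1H-tetrazol-5-yl in place of 5-methyl-1,3,4-thiadiazol-2-yl on a sulfur. Within the data shown here, no step between two measured compounds is available to show what such a change does here. Since compound 1 sits at the limit of > 100000 nM in this assay, at which 2 of the 2 values shown sit, the step of a number no higher from compound 1 to compound 3 (the limit leaves the size open) is expected to be none beyond the scatter, with the result most likely again a limit. Compound 3 is therefore estimated to give about 100000 nM in this assay, within a range from 30000 nM to 300000 nM.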

Compound 3, half-maximal inhibitory concentration: > 100000 nM
Compound 3: a limit, no number; the forecaster's own chance of this, stated with the estimate: 85%; the middle value lies on the limit itself.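

In this assay compound 3 gives > 100000 nM, which is a limit and not a number. Within the data shown here, with compound 1 also at a limit, no step between compound 1 and compound 3 can be read. The compounds shown leave open whether any group on the sulfur changes the antiproliferative activity at all: the limit of > 100000 nM in this assay, at which 3 of the 3 values shown sit.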